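A few compounds are considered here, and "the series" means these few. Any claim that something is new, unique, unknown or untested is made for them only; others in the source may bear on it.

Among the compounds with values here, compound 1 `O=C(O)CCc1ccc(NCc2cccc(Br)c2)cc1` is the one member of this set with an actual number in a functional assay for agonist activity at Free fatty acid receptor 1 (Homo sapiens); on this read-out higher numbers stand for an effect only at larger amounts of compound and lower numbers for an effect already at smaller amounts: in this assay compound 1 gives 794 nM. Compound 2 `O=C(O)CCc1ccc(NCc2ncc[nH]2)cc1` stands differently, for in this assay compound 2 returns only a limit of < 31700 nM and no number. In other words, (the limit of < 31700 nM in this assay, at which 1 of the 2 values shown sits). Compound 3 `CS(=O)(=O)Nc1cccc(CNc2ccc(CCC(=O)O)cc2)c1` is the next compound to be tested in this assay. The change from compound 1 is methanesulfonamido in place of bromo on an aromatic carbon. Within the data shown here, no measured pair in this set covers a change of this kind, so nothing here shows its size directly. The expected step in this assay is a 3.1-fold higher number from compound 1 to compound 3 (0.50 log units; beyond the scatter), a loss of potency somewhat larger than the usual scatter. Compound 3 is therefore estimated at 2500 nM in this assay, within a range from 800 nM to 10000 nM.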

Compound 3, half-maximal effective concentration: < 31700 nM
Compound 3 gave a limit, no number; the forecaster's own chance of this, stated with the estimate: 15%; the middle value lies beyond the limit too.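

In this assay, within the data shown here, compound 3 returns only a limit, so no step from compound 1 to compound 3 can be read: the limit of < 31700 nM in this assay, at which 2 of the 3 values shown sit.

The compounds shown leave open how far methanesulfonamido in place of bromo on an aromatic carbon shifts the potency of compound 1.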